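Oxazole in Place of Carbamoyl: Another Flat Step Expected

A few compounds are considered here, and "the series" means these few. Any claim that something is new, unique, unknown or untested is made for them only; others in the source may bear on it.

Of the compounds shown here, three on the shared core have so far been measured in an assay on membranes from HeLa cells for displacement of a labelled ligand from adenosine receptor A3 (Homo sapiens), read by scintillation counting, with a stated time of 180 min, tested at 1 uM; on this read-out higher numbers stand for more inhibition at the one concentration tested (going by the name of the read-out) and lower numbers for less inhibition. Compound 1 `CC1=C(C(=O)OC(C)(C)C)C(c2ccoc2)NC(=O)N1` gives 2%, compound 2 `CCCC(=O)C1=C(C)NC(=O)NC1c1ccoc1` gives 2%, and compound 3 `CC1=C(C(N)=O)C(c2ccoc2)NC(=O)N1` gives 2%. The steps among them are flat: no change at the digits printed from compound 1 to compound 2 (within the scatter), no change at the digits printed from compound 1 to compound 3 (within the scatter) and no change at the digits printed from compound 2 to compound 3 (within the scatter). Compound 3 thus stands level with compounds 1 and 2. Compound 4 `CC1=C(c2ncc(C)o2)C(c2ccoc2)NC(=O)N1` differs from compound 3 by 5-methyl-1,3-oxazol-2-yl in place of carbamoyl on a double-bonded ring carbon. Among the measured compounds shown here, no measured step exchanges the carbamoyl for an aromatic ring; the three steps that vary the group on a carbonyl carbon all lie within the scatter, so a step of a number 1 percentage points higher from compound 3 to compound 4 (within the scatter) is expected, that is none beyond the scatter. Compound 4 is therefore estimated at 3%, within -5% to 15%.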

Compound 4, a percentage reported as inhibition, at one concentration (the size of the read-out at that concentration, not a potency): 1%
For compound 4 the middle estimate is 2 percentage points above the measured one, within the range that was stated.
By their numbers in this assay, from the lowest: compounds 4, 1, 2 and 3 (each within the scatter of the next).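

Among the compounds shown here, this is the first aromatic ring on this double-bonded ring carbon, and in this assay 5-methyl-1,3-oxazol-2-yl in place of carbamoyl gives a number 1 percentage points lower from compound 3 to compound 4 (within the scatter) and in place of propylcarbonyl gives a number 1 percentage points lower from compound 2 to compound 4 (within the scatter) at this position. Exchanging a group on a carbonyl carbon and exchanging the whole carbonyl-bearing group for this ring thus both stay within the scatter. Nothing available bears on why this exchange leaves the read-out flat.

The compounds shown leave open whether an amine or a carboxylic acid on this ring carbon would read differently. They also leave open what a longer chain in place of the methyl group, or another group in place of furan-3-yl, would do.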